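A few compounds are considered here, and "the series" means these few. Any claim that something is new, unique, unknown or untested is made for them only; others in the source may bear on it.

In a functional assay on HepG2 cells (Homo sapiens) for inhibition, read by MTT assay, with a stated time of 48 h (on this read-out lower numbers stand for stronger inhibition and higher numbers for weaker inhibition), compound 1 `COc1ccc(-n2c(SC)nnc2-c2cc(OC)c(OC)c(OC)c2)cc1` gives > 60000 nM as a limit of the assay, not a number. Compound 2 `COc1ccc(-n2c(SCc3ccc(C)cc3)nnc2-c2cc(OC)c(OC)c(OC)c2)cc1` gives 31600 nM as a measured number. Compound 3 `COc1cc(-c2nnc(SCc3ccc(C)cc3)n2-c2ccc(N(C)C)cc2)cc(OC)c1OC` gives > 60000 nM as a limit too, so it offers no exact starting number. Compound 4 `CCOC(=O)CSc1nnc(-c2cc(OC)c(OC)c(OC)c2)n1-c1ccc(N(C)C)cc1` is still unmeasured. It carries ethoxycarbonyl in place of 4-methylphenyl on a saturated chain carbon bound to a sulfur, a change that reads ethoxycarbonyl in place of 4-methylphenyl on a saturated chain carbon bound to a sulfur when counted. For the measured compounds named here, that same place gave an at least 1.8-fold lower number from compound 1 to compound 2 (0.27 log units; that floor lies within the scatter) in the one comparison there. Compound 4 keeps the dimethylamino group, and bringing it in gave an at least 1.8-fold higher number from compound 2 to compound 3 (0.27 log units; that floor lies within the scatter) as the other step. Both steps lie within the scatter, so no step beyond it is expected. The estimated step is a number no higher from compound 3 to compound 4 (the limit leaves the size open) in this reading. The estimated value for compound 4 is 60000 nM with an expected range from 25000 nM to 120000 nM in this assay here.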

Compound 4, half-maximal inhibitory concentration: > 60000 nM
Compound 4 ended at the assay's limit; the forecaster's own chance of this, stated with the estimate: 65%; the middle value lies on the limit itself.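

Compound 3 and compound 4 both end at a limit of the assay, not at a number, so no step can be read between them: the limit of > 60000 nM in this assay, at which 3 of the 4 values shown sit.

The compounds shown leave open whether 4-methylphenyl or ethoxycarbonyl gives the lower number alongside the dimethylamino group.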